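Replacing the Aryl Group of Compound 1 with Isobutoxy

This account rests on a few compounds, and the source may have more. Where it says the series, first, only, none or still open, it means among the compounds named here.

Of the compounds shown here, three sharing one core have been measured in a functional assay on HEK293 cells for agonist activity at G-protein coupled receptor 39 (Homo sapiens), read by scintillation proximity assay and inositol phosphate accumulation, with a stated time of 75 min; on this read-out lower numbers stand for an effect already at smaller amounts and higher numbers for an effect only at larger amounts of compound. Compound 1 `Cc1nn(-c2ncnc3nc[nH]c23)c2c1C(c1ccc(OC(C)C)cc1)CC(=O)N2` gives 2700 nM, the highest number of the three. Compound 2 `Cc1nn(-c2ncnc3nc[nH]c23)c2c1C(c1ccc(F)cc1Cl)CC(=O)N2` gives 280 nM, and compound 3 `Cc1nn(-c2ncnc3nc[nH]c23)c2c1C(OC(=O)c1ccc(F)cc1)CC(=O)N2` gives 245 nM. Both measured steps that start from compound 1 lowered the number: a 9.6-fold lower number from compound 1 to compound 2 (0.98 log units; beyond the scatter) and an 11-fold lower number from compound 1 to compound 3 (1.04 log units; beyond the scatter). Compound 2 and compound 3 differ by a 1.1-fold lower number from compound 2 to compound 3 (0.06 log units; within the scatter).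

Compound 4 `Cc1nn(-c2ncnc3nc[nH]c23)c2c1C(OCC(C)C)CC(=O)N2` is the compound not yet measured. It differs from compound 1 in one place: isobutoxy in place of 4-isopropoxyphenyl on a saturated ring carbon. The two measured steps bear on this change because in a 9.6-fold lower number from compound 1 to compound 2 (0.98 log units; beyond the scatter) and in an 11-fold lower number from compound 1 to compound 3 (1.04 log units; beyond the scatter) the same 4-isopropoxyphenyl was exchanged for other groups, once for an aryl group and once for an ester-linked aryl group. Isobutoxy is a smaller, non-ring group, so those steps guide only loosely. The step to compound 4 is expected to be a 1.8-fold lower number from compound 1 to compound 4 (0.26 log units; within the scatter), a smaller gain than either measured step. Compound 4 is therefore estimated at 1500 nM, within a range from 300 nM to 7000 nM.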

Compound 4, half-maximal effective concentration: 111 nM
Beside the measured number, compound 4's estimate is 14-fold (1.13 log units) above it; the measured number lies below the stated range.
By their numbers in this assay, from the lowest: compound 4; then compounds 3 and 2 (each within the scatter of the next); then compound 1.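

In this assay, a group on this saturated ring carbon needs no ring to give a low number: isobutoxy, with 5 heavy atoms and no ring in place of the 10 heavy atoms and aromatic ring of 4-isopropoxyphenyl, gives a 24-fold lower number from compound 1 to compound 4 (1.39 log units; beyond the scatter). The result also goes beyond both earlier replacements, with a 2.2-fold lower number from compound 3 to compound 4 (0.34 log units; beyond the scatter) for isobutyl in place of (4-fluorophenyl)carbonyl on the same oxygen and a 2.5-fold lower number from compound 2 to compound 4 (0.40 log units; beyond the scatter) for isobutoxy in place of 2-chloro-4-fluorophenyl, so among these four compounds the only group without a ring gives the lowest number. Nothing available on these compounds accounts for these steps.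

From the compounds shown here alone, whether a shorter chain such as ethoxy or a longer chain such as hexyloxy would move the number further remains open. Also open, going by these compounds, is whether the oxygen matters, which an isobutyl group or an amine on this carbon would test.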